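This account rests on a few compounds, and the source may have more. Where it says the series, first, only, none or still open, it means among the compounds named here.

Three compounds of the series have so far been run in an ADME assay on cells (Homo sapiens) for cytotoxicity, read by polymerase chain reaction, with a stated time of 3 days; a higher number here means that more compound is tolerated, a lower number that less compound is tolerated. Compound 1, `CCOc1ccc2nc(-c3c(Cl)nc(N)nc3N[C@@H]3C[C@H](CO)[C@@H](O)[C@H]3O)sc2c1`, reaches only the limit of the assay: in this assay compound 1 gives > 25000 nM, which is a limit and not a number, as the limit of > 25000 nM in this assay, at which 1 of the 3 values shown sits, records. Compound 2, `CN(C)c1ccc2sc(-c3c(Cl)nc(N)nc3N[C@@H]3C[C@H](CO)[C@@H](O)[C@H]3O)nc2c1`, gives 25000 nM in this assay. Compound 3, `Cc1nc(NC(C)C)nc(N[C@@H]2C[C@H](CO)[C@@H](O)[C@H]2O)c1-c1nc2ccccc2s1`, gives 13000 nM in this assay; this is the lower of the two numbers shown, but the gap to compound 2 lies within the usual scatter, so the two read as the same. For the measured compounds named here, no pair of measured compounds differs in a single place, so no measured step is available to lean on.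

Compound 4, `Cc1nc(NCc2ccsc2)nc(N[C@@H]2C[C@H](CO)[C@@H](O)[C@H]2O)c1-c1nc2ccccc2s1`, is the next compound and has not yet been measured in this assay. It differs from compound 3 in one place: (thiophen-3-yl)methyl in place of isopropyl on a nitrogen on an aromatic ring. Going by the values given here, nothing among the measured compounds exchanges that group, so the effect of the change cannot be read from the data. The expectation is therefore a step no larger than the scatter, a 1.3-fold lower number from compound 3 to compound 4 (0.11 log units; within the scatter), with a slight lean toward less compound being tolerated. For compound 4 the estimated value in this assay is 10000 nM, with a range from 4000 nM to 25000 nM.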

Compound 4, half-maximal cytotoxic concentration: 6000 nM
For compound 4 the middle estimate is 1.7-fold (0.22 log units) above the measured one, within the range that was stated.
By their numbers in this assay, from the lowest: compound 4; then compounds 3 and 2 (each within the scatter of the next).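

For the compounds shown here, replacing isopropyl with (thiophen-3-yl)methyl on a nitrogen on an aromatic ring gives, in this assay, a 2.2-fold lower number from compound 3 to compound 4 (0.34 log units; beyond the scatter) and supplies the first measured single-place step. Going by these compounds alone, the step is modest but lies beyond the scatter, so the group on this nitrogen can shift how much compound is tolerated, something the earlier compounds, with no single-place pair among them, could not show. No measurement given here bears on why the number falls with this change.

Going by these compounds, with one pair, it remains open whether the step follows from the five-membered aromatic ring, from the larger group as a whole, or from the particular attachment through the thiophen-3-yl position. Also open, on these data alone, is where other groups on the same nitrogen would fall relative to compound 3 and compound 4 in this assay, such as a benzyl group, a straight butyl chain, or a chain ending in a carboxylic acid or an amine.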